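The compounds below may be only part of what the source reports. "The series", "measured", "known", "first", "only" and "open" are said of these compounds alone.

Measured compounds:
- compound 1, `CN1CCN(CCNCc2cn(-c3ccc(F)cc3F)nc2-c2ccc(OC(F)(F)F)cc2)CC1`: 18000 nM
- compound 2, `CN1CCN(CCNCc2cn(-c3ccc([N+](=O)[O-])cc3)nc2-c2ccc(C(F)(F)F)cc2)CC1`: 3200 nM
- compound 3, `CCN(CC)CCCNCc1cn(-c2ccc(F)cc2F)nc1-c1ccccc1C`: > 20000 nM

In an ADME assay on Huh-7 cells (Homo sapiens) for cytotoxicity (a higher number here means that more compound is tolerated, a lower number that less compound is tolerated), compound 1 gives 18000 nM and compound 2 gives 3200 nM. For compound 3 this assay reports only a limit, > 20000 nM. Among the measured compounds shown here, compound 3 therefore stands at the limit of > 20000 nM in this assay, at which 1 of the 3 values shown sits; no counted step leads from it to either of the other two, and the values of compound 1 and compound 2 only show that both lie within the measured range.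

Compound 4, `Cc1ccccc1-c1nn(-c2ccc(F)cc2F)cc1CNCCCN1CCN(C)CC1`, differs from compound 3 in one place: 4-methylpiperazin-1-yl in place of diethylamino on a saturated chain carbon, three bonds along the chain from an amine nitrogen. For the measured compounds named here, no measured pair shows this change on its own, so no size or direction can be read from the data. The expected step of a number no higher from compound 3 to compound 4 (the limit leaves the size open) is none beyond the scatter, because compound 3 sits at the limit of > 20000 nM in this assay, at which 1 of the 3 values shown sits, and the change leaves the rest of the structure untouched. Compound 4 is therefore estimated to give 20000 nM in this assay, within a range of 7000 nM to 45000 nM.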

Compound 4, half-maximal cytotoxic concentration: > 20000 nM
Compound 4: no number, only a limit; the forecaster's own chance of this, stated with the estimate: 50%; the middle value sits exactly at the limit.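

In this assay compound 3 and compound 4 both give only a limit, so no step can be read between them: the limit of > 20000 nM in this assay, at which 2 of the 4 values shown sit.

The compounds shown leave open how far 4-methylpiperazin-1-yl in place of diethylamino shifts the concentration tolerated in this assay.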